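Swapping the aryl group on the piperazine nitrogen

The source may hold more compounds than are shown below. What is called first, only, known or untested is meant among the compounds shown, and "the series" means these compounds.

Compound 2 `CCCn1c(=O)[nH]c2nc(-c3ccc(S(=O)(=O)N4CCN(c5ccc(Br)cc5)CC4)cc3)[nH]c2c1=O` stands lowest of the three measured compounds in an assay on CHO cells for displacement of a labelled ligand from adenosine receptor A2b (Homo sapiens), read by scintillation counting, with a stated time of 75 min, in the presence of a further agent that is not named here (on this read-out higher numbers stand for weaker inhibition and lower numbers for stronger inhibition), where compound 2 gives 0.0835 nM. Compound 3 `CCCn1c(=O)[nH]c2nc(-c3ccc(S(=O)(=O)N4CCN(c5cccc(Cl)c5)CC4)cc3)[nH]c2c1=O` is nearest, and in this assay compound 3 gives 0.342 nM. Compound 1 `CCCn1c(=O)[nH]c2nc(-c3ccc(S(=O)(=O)N4CCN(c5ccc(Cl)cc5F)CC4)cc3)[nH]c2c1=O` lies furthest away, and in this assay compound 1 gives 1.91 nM.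

Compound 4 `CCCn1c(=O)[nH]c2nc(-c3ccc(S(=O)(=O)N4CCN(c5ccccc5F)CC4)cc3)[nH]c2c1=O` is not yet measured. The change from compound 2 to compound 4 is 2-fluorophenyl in place of 4-bromophenyl on an amine nitrogen in a ring. Going by the values given here, two measured steps bear on it. The step of a 23-fold lower number from compound 1 to compound 2 (1.36 log units; beyond the scatter) shows that a phenyl carrying a 2-fluoro group together with a 4-chloro group gave a far higher number than the 4-bromophenyl. The step of a 4.1-fold higher number from compound 2 to compound 3 (0.61 log units; beyond the scatter) shows that moving away from 4-bromophenyl to 3-chlorophenyl also raised the number. Compound 4 carries only a 2-fluoro group, so both the loss of the bromine and the presence of fluorine at the 2-position point the same way, and a higher number is expected for compound 4, an expected step of a 36-fold higher number from compound 2 to compound 4 (1.56 log units; beyond the scatter) from compound 2 to compound 4. The estimate for compound 4 in this assay is 3 nM, with a range from 0.6 nM to 15 nM.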

Compound 4, inhibition constant: 3.22 nM
Compound 4: the middle estimate sits 1.1-fold (0.03 log units) below what was measured, and the stated range covers the measured number.
By their numbers in this assay, from the lowest: compound 2; then compound 3; then compounds 1 and 4 (each within the scatter of the next).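

With the 2-fluorophenyl group on the amine nitrogen in the ring, the read-out in this assay stands well above that of both compounds lacking fluorine (a 39-fold higher number from compound 2 to compound 4 (1.59 log units; beyond the scatter)) and (a 9.4-fold higher number from compound 3 to compound 4 (0.97 log units; beyond the scatter)). The result also separates the two halogens of compound 1: with the 2-fluoro group kept, hydrogen in place of chloro on the aromatic carbon leaves the number within the scatter (a 1.7-fold higher number from compound 1 to compound 4 (0.23 log units; within the scatter)), so no effect of that chloro group can be read here. Earlier, the high number of compound 1 could not be assigned to either halogen, whereas now both compounds carrying the 2-fluoro group stand above both compounds without it, and none of the four goes against this. Nothing shown here gives a reason for these differences.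

The compounds shown leave open where the unsubstituted phenyl group would fall, since every aryl group here carries at least one halogen. They also leave open whether the high numbers belong to fluorine itself or would return with another group in its place, such as the chlorine of a 2-chlorophenyl group or the methoxy of a 2-methoxyphenyl group.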